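Compound 3 to Compound 4: Changing the Aryl Ring Pattern

The source may report more compounds than this note shows. Statements on the series, on what has been measured and on what is new or still open speak of the compounds shown alone.

Three compounds have been tested in a functional assay on KB cells (Homo sapiens) for antiproliferative activity, read by sulforhodamine B assay, with a stated time of 3 days; a lower number here means that less compound is needed, a higher number that more compound is needed for the effect:

- compound 1, `CCC1=C(O)c2c(oc(-c3ccc(CC)cc3)cc2=O)C(CC)(CC)C1=O`, gives 21.9 uM
- compound 2, `CCOc1ccc(-c2cc(=O)c3c(o2)C(CC)(CC)C(=O)C(CC)=C3O)cc1`, reaches only a limit of this assay, > 52.4 uM
- compound 3, `CCC1=C(O)c2c(oc(-c3ccc(C)c(Cl)c3)cc2=O)C(CC)(CC)C1=O`, gives 39 uM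

Among the two numbers, compound 3 has the highest; the nearest is compound 1, and a 1.8-fold higher number from compound 1 to compound 3 (0.25 log units; within the scatter), a gap within the scatter. Compound 2 sits at the limit described by the limit of > 52.4 uM in this assay, at which 1 of the 3 values shown sits, so only a floor is known for an at least 1.3-fold lower number from compound 2 to compound 3 (0.12 log units; that floor lies within the scatter), and that floor lies within the scatter. Going by the values given here, the one step beyond the scatter is an at least 2.3-fold higher number from compound 1 to compound 2 (0.37 log units; beyond the scatter).

Compound 4, `CCC1=C(O)c2c(oc(-c3cc(C)ccc3F)cc2=O)C(CC)(CC)C1=O`, has not yet been measured. It differs from compound 3 only in the aryl group: 2-fluoro-5-methylphenyl in place of 3-chloro-4-methylphenyl on an aromatic carbon. Among the compounds with values here, the steps that bear on it are the swaps of one aryl group for another on the shared core, and of those, the change from compound 1 to compound 3 stayed within the scatter, while the ethoxy change stood apart. A halogen-and-methyl pattern remains in compound 4, so no step beyond the scatter is expected, a 1.1-fold lower number from compound 3 to compound 4 (0.05 log units; within the scatter). Compound 4 is therefore estimated at 35 uM in this assay, between 15 uM and 70 uM.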

Compound 4, concentration for half-maximal effect: 47.3 uM
Beside the measured number, compound 4's estimate is 1.4-fold (0.13 log units) below it; low and high end bracket the measured number.
By their numbers in this assay, from the lowest: compounds 1, 3 and 4 (each within the scatter of the next, the first and the last beyond it). At a limit, above all of these: compound 2.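

Replacing 3-chloro-4-methylphenyl with 2-fluoro-5-methylphenyl on this aromatic carbon, next to the ring oxygen, changes the halogen and the ring pattern together, and in this assay the step is a 1.2-fold higher number from compound 3 to compound 4 (0.08 log units; within the scatter), so the two compounds cannot be told apart. Set against the 4-ethylphenyl group, the same 2-fluoro-5-methylphenyl group gives a 2.2-fold higher number from compound 1 to compound 4 (0.33 log units; beyond the scatter), a modest step beyond the scatter, whereas a 1.8-fold higher number from compound 1 to compound 3 (0.25 log units; within the scatter) stays within it, so two small gaps that each lie within the scatter can add up to one that does not. Compound 2 stands at a limit: the limit of > 52.4 uM in this assay, at which 1 of the 4 values shown sits. Only a floor can be given for the remaining step, an at least 1.1-fold lower number from compound 2 to compound 4 (0.04 log units; that floor lies within the scatter).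

Every aryl group shown carries only halogen, alkyl or ethoxy substituents, which leaves open how a ring bearing an amine or a carboxylic acid would fare on the shared core. Fluorine for chlorine and the shift in ring pattern also arrive together in compound 4, and no compound shown carries either change alone, so their separate contributions remain unknown.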